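This account rests on a few compounds, and the source may have more. Where it says the series, first, only, none or still open, it means among the compounds named here.

Compound 1 `N#CC1=C(N)Oc2c(c3nc4ccccc4nc3c3ccccc23)C12C(=O)N(Cc1cnnn1-c1cccc(S(N)(=O)=O)c1)c1ccccc12`: 44200 nM
Compound 2 `Cc1ccc(C)c(-n2nncc2CN2C(=O)C3(C(C#N)=C(N)Oc4c3c3nc5ccccc5nc3c3ccccc43)c3ccccc32)c1`: > 50000 nM
Compound 3 `N#CC1=C(N)Oc2c(N)cc3nc4ccccc4nc3c2C12C(=O)N(Cc1cnnn1-c1ccccc1Br)c1ccccc12`: 27400 nM

In a functional assay on A549 cells (Homo sapiens) for antiproliferative activity, read by MTT assay, with a stated time of 48 h (a higher number here means a weaker inhibitor, a lower number a stronger inhibitor), compound 3 gives 27400 nM, the lower of the two numbers recorded, though the gap to compound 1 lies within the scatter. Compound 1 gives 44200 nM in this assay. For compound 2 the reading is only a limit of the assay, > 50000 nM, and the limit of > 50000 nM in this assay, at which 1 of the 3 values shown sits, shows where that limit sits.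

Compound 4 `Cc1cc(C)cc(-n2nncc2CN2C(=O)C3(C(C#N)=C(N)Oc4c(N)cc5nc6ccccc6nc5c43)c3ccccc32)c1` differs from compound 3 in one place: 3,5-dimethylphenyl in place of 2-bromophenyl on an aromatic nitrogen. Among the measured compounds shown here, the one measured step that speaks to this change is an at least 1.1-fold higher number from compound 1 to compound 2 (0.05 log units; that floor lies within the scatter), where a dimethylphenyl likewise entered on the aromatic nitrogen and the number rose to the limit. On that evidence a rise in the number is expected for compound 4, an estimated step of a 1.6-fold higher number from compound 3 to compound 4 (0.22 log units; within the scatter), with a fair chance that the reading ends as a limit rather than a number. Compound 4 is therefore expected to give about 45000 nM in this assay, within a range from 20000 nM to 100000 nM.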

Compound 4, half-maximal inhibitory concentration: 31200 nM
The estimate for compound 4 lay 1.4-fold (0.16 log units) above the measured number; the measured number falls inside the stated range.
By their numbers in this assay, from the lowest: compounds 3, 4 and 1 (each within the scatter of the next). At a limit, above all of these: compound 2.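

In this assay the change from 2-bromophenyl to 3,5-dimethylphenyl on the aromatic nitrogen gives a 1.1-fold higher number from compound 3 to compound 4 (0.06 log units; within the scatter), so the two groups cannot be told apart at this position on this core. Among the compounds shown here, this is the first step at this position with a number at both ends, and it shows that a dimethylphenyl group here need not end at a limit of the assay. For compound 2 the reading is a limit, so the earlier step gave only a floor: the limit of > 50000 nM in this assay, at which 1 of the 4 values shown sits.

From the compounds shown here alone, whether the 2,5-dimethylphenyl and 3,5-dimethylphenyl groups differ on one and the same core stays open. So does whether an amine, a carboxylic acid or a longer alkyl chain in this place would move the number beyond the scatter.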